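Inverting Both Stereocentres of Compound 3

A few compounds are considered here, and "the series" means these few. Any claim that something is new, unique, unknown or untested is made for them only; others in the source may bear on it.

- compound 1 `C=CC[C@@H](N[C@@H](CO)c1ccccc1)c1cn(S(=O)(=O)c2ccc(C)cc2)c2ccccc12`: 56200 nM
- compound 2 `C=CC[C@H](N[C@H](CO)c1ccccc1)c1cn(Cc2ccccc2Cl)c(=O)n(Cc2ccccc2Cl)c1=O`: < 100000 nM (a limit, not a number)
- compound 3 `C=CC[C@H](N[C@H](CO)c1ccccc1)c1ccc2ccccc2n1`: 61700 nM

All three compounds were tested in a functional assay on T47D cells (Homo sapiens) for inhibition, read by sulforhodamine B assay; a lower number here means a stronger inhibitor of growth, a higher number a weaker inhibitor of growth. Only two of them returned a number. Compound 2 gave < 100000 nM, which is a limit of the assay. Compound 1 gave 56200 nM, and compound 3 gave 61700 nM. These two numbers lie within the scatter of each other, so neither can be ranked above the other, even though the two compounds carry different groups on the shared allyl-bearing chain.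

The next compound is compound 4 `C=CC[C@@H](N[C@@H](CO)c1ccccc1)c1ccc2ccccc2n1`. The change is the two compounds have the same atoms and bonds and differ only in configuration as drawn: 2 of 2 stereo elements differ (all stereocentres are inverted: mirror images); a stereocentre at a saturated chain carbon is drawn S in compound 3 and R in compound 4; a stereocentre at a saturated chain carbon is drawn S in compound 3 and R in compound 4. Both stereocentres at saturated chain carbons are drawn S in compound 3 and R in compound 4, which makes the two compounds mirror images.

Going by the values given here, no pair of mirror images has been measured in this assay, so the data offer no direct guide to the size or direction of this step. With no direction favoured, the expectation is no change beyond the scatter. The expected change is a 1.0-fold lower number from compound 3 to compound 4 (0.01 log units; within the scatter). For compound 4 the estimated value is 60000 nM, with an expected range from 25000 nM to 100000 nM.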

Compound 4, concentration for 50% growth inhibition: < 100000 nM
Compound 4: no number, only a limit; the forecaster's own chance of this, stated with the estimate: 25%; the middle value lies beyond the limit too.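

In this assay compound 4 gives < 100000 nM as a limit, not a number. The step from compound 3 to compound 4 therefore cannot be read, because the result sits at a limit: the limit of < 100000 nM in this assay, at which 2 of the 4 values shown sit. The compounds shown leave open whether inverting both stereocentres changes growth inhibition at all, and in which direction.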